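The compounds below may be only part of what the source reports. "The series", "measured", "known", "first", "only" and "open" are said of these compounds alone.

Compound 1 `CC(C)(C)NC(=O)COC(=O)c1ccc([N+](=O)[O-])o1`: > 100000 nM (a limit)
Compound 2 `O=C(COC(=O)c1ccc([N+](=O)[O-])o1)NC1CCc2ccccc21`: > 100000 nM (a limit)

In an ADME assay on HEK-293T cells (Homo sapiens) for cytotoxicity, read by MTT assay, with a stated time of 3 days (on this read-out lower numbers stand for higher toxicity in this test and higher numbers for lower toxicity in this test), compound 1 gives > 100000 nM, which is a limit and not a number. Compound 2 likewise gives only a limit, > 100000 nM. Together the two make up (the limit of > 100000 nM in this assay, at which 2 of the 2 values shown sit), so compound 1 shares its place with the only other compound measured, and no measured step is available to serve as a guide.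

Compound 3 `COc1ccc(CN(C(=O)COC(=O)c2ccc([N+](=O)[O-])o2)C(C)(C)C)cc1` has not yet been measured. It keeps the core of compound 1 and differs at one place: 4-methoxybenzyl in place of hydrogen on an amide-type nitrogen, with 4-methoxybenzyl in place of hydrogen on an amide-type nitrogen.

The expectation of little change rests on the limit that compound 2 also reaches, > 100000 nM. Expected here is an at least 1.2-fold lower number from compound 1 to compound 3 (0.09 log units; that floor lies within the scatter), small and toward lower numbers in this assay, and possibly no larger than the usual scatter. A report of only a limit would be no surprise. For compound 3 the estimated value is 80000 nM, with an expected range from 25000 nM to 100000 nM.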

Compound 3, half-maximal cytotoxic concentration: > 100000 nM
Compound 3: a limit, no number; the forecaster's own chance of this, stated with the estimate: 60%; middle value at least 1.2-fold (0.09 log units) away from the limit.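

In this assay compound 3 gives > 100000 nM, which is a limit and not a number. Compound 1 likewise gives only a limit, > 100000 nM. No step can be read from compound 1 to compound 3: the limit of > 100000 nM in this assay, at which 3 of the 3 values shown sit. The compounds shown leave open whether 4-methoxybenzyl in place of hydrogen on the amide-type nitrogen changes the read-out at all.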